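Adding a chloro group to the aromatic ring of compound 1

This account rests on a few compounds, and the source may have more. Where it says the series, first, only, none or still open, it means among the compounds named here.

For the measured compounds named here, compound 1 `COC(=O)[C@@]1(C)CCC=C2[C@@H]1CC[C@@H](C)[C@]2(C)Cc1c[nH]c2ccccc12` gives 4200 nM in a functional assay on T47D cells (Homo sapiens) for inhibition, read by sulforhodamine B assay, with a stated time of 48 h (on this read-out lower numbers stand for stronger inhibition of growth and higher numbers for weaker inhibition of growth), the lowest of the three numbers measured so far. Compound 2 `COC(=O)[C@@]1(C)CCC=C2[C@@H]1CC[C@@H](C)[C@]2(C)Cc1c[nH]c2ccc(C)cc12` gives 20000 nM and compound 3 `COC(=O)[C@@]1(C)CCC=C2[C@@H]1CC[C@@H](C)[C@]2(C)Cc1c[nH]c2ccc(C(F)(F)F)cc12` gives 15000 nM. Compound 4 `COC(=O)[C@@]1(C)CCC=C2[C@@H]1CC[C@@H](C)[C@]2(C)Cc1c[nH]c2c(Cl)cccc12` carries chloro in place of hydrogen on an aromatic carbon. Going by the values given here, two measured steps bear on this change, each placing a small group on an aromatic carbon of the shared core: a 4.8-fold higher number from compound 1 to compound 2 (0.68 log units; beyond the scatter) and a 3.6-fold higher number from compound 1 to compound 3 (0.55 log units; beyond the scatter), both modest rises beyond the scatter. Among the compounds with values here, a modest rise in this assay is therefore expected for compound 4 as well, although chloro enters at a place of its own and no measured step covers exactly that place. Compound 4 is estimated at 9000 nM, ranging from 3000 nM to 27000 nM, which would be a step of a 2.1-fold higher number from compound 1 to compound 4 (0.33 log units; beyond the scatter).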

Compound 4, concentration for 50% growth inhibition: 24000 nM
Compound 4: the middle estimate sits 2.7-fold (0.43 log units) below what was measured; low and high end bracket the measured number.
By their numbers in this assay, from the lowest: compound 1; then compounds 3, 2 and 4 (each within the scatter of the next).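

Chloro on this aromatic carbon, ortho to a fused ring and meta to a fused ring, also weakens growth inhibition, with a 5.7-fold higher number from compound 1 to compound 4 (0.76 log units; beyond the scatter). A third group at a new place on the ring thus gives a higher number than the unsubstituted compound 1, and no compound shown goes against this. Nothing shown explains the rise. From the compounds shown here alone, it remains open whether a smaller fluoro or an amine at this same carbon would keep the number near that of compound 1, and whether a carboxylic acid in place of the methyl ester would change it.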